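Moving the Sulfonamide Substituent from Benzyl to 2-Methylphenyl

This account rests on a few compounds, and the source may have more. Where it says the series, first, only, none or still open, it means among the compounds named here.

On these data alone, compound 1 `O=C(Nc1ccc(S(=O)(=O)NCc2ccccc2)cc1)c1ccc(Cl)cc1Cl` has only "not determined" (no result reported) in a functional assay on HEK293 cells for agonist activity at probable G-protein coupled receptor 27 (Homo sapiens), read by a luciferase reporter and beta-arrestin recruitment, with a stated time of 10 min (a lower number here means a smaller maximal response, a higher number a larger maximal response), so its own standing on this scale is unknown. Two related compounds frame the range: compound 2 `N#Cc1ccc(C(=O)Nc2ccc(S(=O)(=O)Nc3ccccc3)cc2)c(F)c1` gives 29% in this assay, while compound 3 `O=C(Nc1ccc(S(=O)(=O)Nc2ccccc2)cc1)c1ccc2ccccc2c1` gives 115%. Compound 4 `Cc1ccccc1NS(=O)(=O)c1ccc(NC(=O)c2ccc(Cl)cc2Cl)cc1` differs from compound 1 in one place: 2-methylphenyl in place of benzyl on a sulfonamide nitrogen. Among the compounds with values here, because no measured step starts from compound 1, the size and direction of this change cannot be read from any pair here; it may shift the maximal response either way or not beyond the usual scatter. Compound 4 is therefore expected to reach about 70%, within a wide range from 25% to 115%.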

Compound 4, largest response reached (Emax), in percent of the reference or control that the assay uses: 32%
The estimate for compound 4 lay 38 percentage points above the measured number, and the stated range covers the measured number.
By their numbers in this assay, from the lowest: compounds 2 and 4 (each within the scatter of the next); then compound 3.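

No step can be read between compound 1 and compound 4 in this assay, and no evidence here bears on the result. On these data alone, what replacing benzyl with 2-methylphenyl does to the maximal response stays open.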